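This account rests on a few compounds, and the source may have more. Where it says the series, first, only, none or still open, it means among the compounds named here.

Measured so far:
Compound 1, `CCOCCOc1cccc2ccc(N)nc12`, in an assay on cells with melanin-concentrating hormone receptor 1 (Homo sapiens) as the target, read by radioligand binding (on this read-out higher numbers stand for weaker inhibition and lower numbers for stronger inhibition), gives only a limit of the assay, > 2000 nM.
Compound 2, `Nc1ccc2cccc(OC3CCCCCC3)c2n1`, gives 137 nM in this assay.
Compound 3, `CCC#CCOc1cccc2ccc(N)nc12`, gives only a limit in this assay, > 2000 nM.

Compound 1 therefore stands at a limit and has no number of its own. Among the compounds with values here, the one measured step, a step that the two limits leave unreadable from compound 1 to compound 3, cannot be read because both of its ends sit at the limit of > 2000 nM in this assay, at which 2 of the 3 values shown sit.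

Compound 4, `CC1CCC(Oc2cccc3ccc(N)nc23)C1`, differs from compound 1 in one place: 3-methylcyclopentyl in place of 2-ethoxyethyl on an oxygen on an aromatic ring. Within the data shown here, no measured step covers this change, so its size must be judged from the compounds themselves. Compound 2 also carries a saturated carbon ring on the oxygen on the aromatic ring, and compound 2 gives 137 nM, well inside the measurable range. Compound 4 is therefore expected to move off the limit toward stronger inhibition, a step beyond the scatter, an at least 6.6-fold lower number from compound 1 to compound 4 (0.82 log units; beyond the scatter). The estimate for compound 4 is 300 nM, expected to fall between 80 nM and 1500 nM.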

Compound 4, half-maximal inhibitory concentration: 823 nM
Compound 4: the middle estimate sits 2.7-fold (0.44 log units) below what was measured; low and high end bracket the measured number.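

Putting 3-methylcyclopentyl in place of 2-ethoxyethyl on an oxygen on an aromatic ring gives an at least 2.4-fold lower number from compound 1 to compound 4 (0.38 log units; beyond the scatter) in this assay. The same ring in place of pent-2-yn-1-yl gives an at least 2.4-fold lower number from compound 3 to compound 4 (0.38 log units; beyond the scatter), so among the compounds shown, the two with a saturated carbon ring on this oxygen have numbers of their own, while the two with open chains do not. Both steps are minimum sizes, and the true distance cannot be read, since compound 1 and compound 3 each stand at a limit of the assay: the limit of > 2000 nM in this assay, at which 2 of the 4 values shown sit.

The step between the two open chains cannot be read either, so the compounds shown do not rank those chains against each other. On these data alone, whether a ring holding an amine, such as a piperidine, would also give a measurable number on this oxygen remains open.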